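The source may report more compounds than this note shows. Statements on the series, on what has been measured and on what is new or still open speak of the compounds shown alone.

In a functional assay on cells for agonist activity at Free fatty acid receptor 1 (Homo sapiens), read by FLIPR and calcium flux (a lower number here means a smaller maximal response, a higher number a larger maximal response), three compounds have been measured so far. Compound 1 `Cc1cc(CCC(=O)O)ccc1OCc1ccccc1SC(F)(F)F` gives 81%. Compound 2 `Cc1cc(CCC(=O)O)cc(C)c1OCc1ccccc1SC(F)(F)F` gives 115%, and compound 3 `Cc1cc(CCC(=O)O)ccc1OCc1ccccc1Cl` gives 80%. Compound 2 differs from compound 1 by methyl in place of hydrogen on an aromatic carbon, and with this change the largest response came out a number 34 percentage points higher from compound 1 to compound 2 (beyond the scatter). Compound 3 differs from compound 1 by chloro in place of (trifluoromethyl)sulfanyl on an aromatic carbon, and here the largest response came out a number 1 percentage points lower from compound 1 to compound 3 (within the scatter), which is no real difference.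

Compound 4 `Cc1ccc(Cl)c(COc2ccc(CCC(=O)O)cc2C)c1` has not yet been measured. It differs from compound 3 by methyl in place of hydrogen on an aromatic carbon. This is the same kind of change as from compound 1 to compound 2, but not the same change: there the methyl entered ortho to a large group, meta to a 2-carboxyethyl group and meta to a methyl group, whereas in compound 4 it enters meta to a large group and para to a chloro group. Going by the values given here, the only earlier example of this kind of change is the step of a number 34 percentage points higher from compound 1 to compound 2 (beyond the scatter). Since the place differs, only part of that rise is expected to carry over, and in this assay the expected step is a number 10 percentage points higher from compound 3 to compound 4 (within the scatter). The largest response of compound 4 is estimated at 90%, most likely between 70% and 112%.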

Compound 4, largest response reached (reported as percent of maximum), in percent of the reference or control that the assay uses: 243%
Compound 4: the middle estimate sits 153 percentage points below what was measured; measured number outside the range, above it.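

In this assay the largest response came out a number 163 percentage points higher from compound 3 to compound 4 (beyond the scatter) with methyl in place of hydrogen on an aromatic carbon. Both examples of this change go upward, but the size of the rise does not carry over from one core to the other: the same change on two cores in this assay, a number 34 percentage points higher (beyond the scatter) from compound 1 to compound 2 and a number 163 percentage points higher (beyond the scatter) from compound 3 to compound 4, 129 percentage points apart, beyond the scatter of two such steps

What these two steps do not show is where the difference comes from. Going by these compounds alone, in compound 4 the methyl sits meta to a large group and para to a chloro group, a different place from the one it takes in compound 2, and the two cores also differ in carrying chloro or (trifluoromethyl)sulfanyl, so place and core cannot be told apart here.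

From the compounds shown here alone, it remains open what a methyl would do in the place it takes in compound 4 on the core of compound 1, and in the place it takes in compound 2 on the core of compound 3. Also open, going by these compounds, is whether an ethyl, a methoxy or a fluoro group in the place of the new methyl would give a similar response.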